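Swapping the cyclic amine on a chain amide series

This account rests on a few compounds, and the source may have more. Where it says the series, first, only, none or still open, it means among the compounds named here.

Measured so far:
- compound 1, `O=C(CC(CC(=O)NC1Cc2ccccc2C1)c1ccc(Cl)cc1)NCCN1CCCCC1`: 28000 nM
- compound 2, `O=C(CC(CC(=O)NC1Cc2ccccc2C1)c1ccc(Cl)cc1)NCCN1CCCC1`: 50900 nM
- compound 3, `CCN(C(=O)CC(CC(=O)NCCN1CCCCC1)c1ccc(Cl)cc1)C1Cc2ccccc2C1`: 13200 nM

All three were tested in a functional assay on A549 cells (Homo sapiens) for inhibition; on this read-out higher numbers stand for weaker inhibition and lower numbers for stronger inhibition. Compound 1 carries a piperidine ring at the end of a two-carbon chain. Compound 2 differs from it in one place: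

pyrrolidin-1-yl in place of piperidin-1-yl on a saturated chain carbon, two bonds along the chain from an amide-type nitrogen

That change gave a 1.8-fold higher number from compound 1 to compound 2 (0.26 log units; within the scatter). Compound 3 instead differs from compound 1 at the other amide, where the core changes:

ethyl in place of hydrogen on an amide-type nitrogen

Here the step was a 2.1-fold lower number from compound 1 to compound 3 (0.33 log units; beyond the scatter), so compound 3 gives the lowest number of the three.

Compound 4, `CCN(C(=O)CC(CC(=O)NCCN1CCCC1)c1ccc(Cl)cc1)C1Cc2ccccc2C1`, has not yet been measured. It stands to compound 3 as compound 2 stands to compound 1:

pyrrolidin-1-yl in place of piperidin-1-yl on a saturated chain carbon, two bonds along the chain from an amide-type nitrogen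

The place is the same in both pairs, so this is the same change made on a different core. Since the earlier step, from compound 1 to compound 2, stayed within the usual scatter, a step of similar size is expected here, estimated as a 1.8-fold higher number from compound 3 to compound 4 (0.26 log units; within the scatter). Compound 4 is therefore expected to give about 24000 nM in this assay, most likely between 10000 nM and 55000 nM.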

Compound 4, half-maximal inhibitory concentration: 22600 nM
The estimate for compound 4 lay 1.1-fold (0.03 log units) above the measured number; measured number inside the range.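

In this assay, the swap from piperidin-1-yl to pyrrolidin-1-yl gave a 1.7-fold higher number from compound 3 to compound 4 (0.23 log units; within the scatter), which matches the step seen on the core of compound 1: the same change on two cores in this assay, a 1.8-fold higher number (0.26 log units; within the scatter) from compound 1 to compound 2 and a 1.7-fold higher number (0.23 log units; within the scatter) from compound 3 to compound 4, 1.1-fold (0.03 log units) apart, within the scatter of two such steps. Putting ethyl in place of the amide hydrogen gave a 2.3-fold lower number from compound 2 to compound 4 (0.35 log units; beyond the scatter), so that step also held with either cyclic amine at the end of the chain: the same change on two cores in this assay, a 2.1-fold lower number (0.33 log units; beyond the scatter) from compound 1 to compound 3 and a 2.3-fold lower number (0.35 log units; beyond the scatter) from compound 2 to compound 4, 1.1-fold (0.03 log units) apart, within the scatter of two such steps. Across these four compounds the two changes therefore add up simply, but this is one pair of cores in one assay, and the ring swap stays within the scatter on both, so it shows neither a real effect of the swap nor that the agreement would hold on other cores.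

Still open, as far as these compounds go, is how other amines at the chain end, such as morpholine or dimethylamino, or a longer chain than 2-(piperidin-1-yl)ethyl, would behave. Also open, from the compounds shown here alone, is how propyl or benzyl in place of ethyl on the amide-type nitrogen would move the number.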